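From carboxy to hydroxymethyl on the shared core

The source may hold more compounds than are shown below. What is called first, only, known or untested is meant among the compounds shown, and "the series" means these compounds.

Values in a functional assay on Maver1 cells (Homo sapiens) for inhibition, read by luminescence and CellTiter-Glo, with a stated time of 72 h (on this read-out lower numbers stand for stronger inhibition and higher numbers for weaker inhibition), for the measured compounds
Compound 1 `O=C(CCl)N1CCCC(n2nc(-c3ccc(Oc4ccccc4)cc3)cc2CO)C1` gives 1100 nM
Compound 2 `C/C=C/C(=O)N1CCCC(n2nc(-c3ccc(Oc4ccccc4)cc3)cc2C(=O)OCC)C1` gives 19600 nM
Compound 3 `C/C=C/C(=O)N1CCCC(n2nc(-c3ccc(Oc4ccccc4)cc3)cc2C(=O)O)C1` gives > 60000 nM (a limit, not a number)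

For compound 3 the reading > 60000 nM is a limit of this assay and not a number. Compound 4 `C/C=C/C(=O)N1CCCC(n2nc(-c3ccc(Oc4ccccc4)cc3)cc2CO)C1` has hydroxymethyl in place of carboxy on an aromatic carbon. Within the data shown here, the one measured step at this group is an at least 3.0-fold higher number from compound 2 to compound 3 (0.48 log units; beyond the scatter) (the ethyl ester giving way to the carboxy group). Nearby evidence comes from compound 1, which gives 1100 nM while also carrying hydroxymethyl, though its amide group differs. On those two readings, leaving carboxy is expected to lower the number, probably to a level nearer compound 1 and compound 2 than the limit. In this assay the estimated change is an at least 7.5-fold lower number from compound 3 to compound 4 (0.87 log units; beyond the scatter) (a lower number, expected to lie beyond the scatter). For compound 4 the expected value is 8000 nM (estimated range 2000 nM to 30000 nM).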

Compound 4, half-maximal inhibitory concentration: > 60000 nM
Compound 4: no number, only a limit; the forecaster's own chance of this, stated with the estimate: 8%; at least 7.5-fold (0.87 log units) between middle value and limit.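

In this assay compound 4 gives > 60000 nM, which is a limit and not a number, so hydroxymethyl on this aromatic carbon does not restore a readable value while prop-1-en-1-yl sits on the carbonyl carbon. Hydroxymethyl in place of ethoxycarbonyl gives an at least 3.0-fold higher number from compound 2 to compound 4 (0.48 log units; beyond the scatter), and with hydroxymethyl held fixed, prop-1-en-1-yl in place of chloromethyl gives an at least 54-fold higher number from compound 1 to compound 4 (1.73 log units; beyond the scatter), so the change on the carbonyl carbon is the larger of the two readable steps. The step between the carboxy and hydroxymethyl compounds cannot be read, because both readings are limits: the limit of > 60000 nM in this assay, at which 2 of the 4 values shown sit.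

As far as these compounds go, it remains open how chloromethyl on the carbonyl carbon would read with ethoxycarbonyl or carboxy at this position. Also open, from the compounds shown here alone, is whether an amine or a longer chain on this aromatic carbon would give a readable number alongside prop-1-en-1-yl.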